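Fluorine on the benzoyl ring of a sulfoxide analogue

The source may report more compounds than this note shows. Statements on the series, on what has been measured and on what is new or still open speak of the compounds shown alone.

Compound 1: `O=C(c1ccccc1)N1CCC(NCCSC(c2ccc(F)cc2)c2ccc(F)cc2)CC1`, 4.51 nM
Compound 2: `O=C(c1ccc(F)cc1)N1CCC(NCCSC(c2ccc(F)cc2)c2ccc(F)cc2)CC1`, 7.04 nM
Compound 3: `O=C(c1ccccc1)N1CCC(NCC[S+]([O-])C(c2ccc(F)cc2)c2ccc(F)cc2)CC1`, 79.1 nM

Of the compounds shown here, three have been measured in an assay on membranes from striatum (strain Sprague-Dawley) for displacement of a labelled ligand from sodium-dependent dopamine transporter (Rattus norvegicus), read by scintillation counting, with a stated time of 120 min (a lower number here means a stronger inhibitor, a higher number a weaker inhibitor), and a fourth, compound 4 with structure `O=C(c1ccc(F)cc1)N1CCC(NCC[S+]([O-])C(c2ccc(F)cc2)c2ccc(F)cc2)CC1`, awaits measurement.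

Compound 1 and compound 2 share a core and differ by one change, (fluoro in place of hydrogen on an aromatic carbon). In this assay this change gave a 1.6-fold higher number from compound 1 to compound 2 (0.19 log units; within the scatter), so the two values sit together within the usual spread of repeated measurements.

Compound 3 carries a different core; the difference between the two cores is not broken down here. In this assay compound 3 gives 79.1 nM, the highest of the three numbers, well beyond the scatter from both compound 1 and compound 2.

Compound 4 stands to compound 3 as compound 2 stands to compound 1: the change is fluoro in place of hydrogen on an aromatic carbon, with the place of the change described in the same words in both pairs, so it is the same change on a different core. The expectation for compound 4 is a step of a 1.3-fold higher number from compound 3 to compound 4 (0.12 log units; within the scatter) in this assay, because the same change on the other core gave a 1.6-fold higher number from compound 1 to compound 2 (0.19 log units; within the scatter). Compound 4 is therefore expected to give 105 nM in this assay, with an estimated range from 45 nM to 240 nM. This expectation rests on a single measured pair, and the new core could respond differently.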

Compound 4, inhibition constant: 77.2 nM
The estimate for compound 4 lay 1.4-fold (0.13 log units) above the measured number, within the range that was stated.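

In this assay, fluoro in place of hydrogen on the benzoyl ring, para to a large group, gave a 1.0-fold lower number from compound 3 to compound 4 (0.01 log units; within the scatter), so the two values on the core of compound 3 sit together within the usual spread of repeated measurements. This shows only that, for these two pairs, the change left the number within the scatter on each core; it does not show that the change is without effect on every core in the series, and two pairs tested in one assay cannot establish a general rule. Within those limits the change carried from one core to the other, since the steps on the two cores cannot be told apart: the same change on two cores in this assay, a 1.6-fold higher number (0.19 log units; within the scatter) from compound 1 to compound 2 and a 1.0-fold lower number (0.01 log units; within the scatter) from compound 3 to compound 4, 1.6-fold (0.20 log units) apart, within the scatter of two such steps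

The compounds shown leave open whether a larger group in the same place, such as chloro, methoxy or trifluoromethyl, would also give matching steps on the two cores. They also leave open how the same fluoro change would read on a third core, for example one carrying a sulfone in the chain or a plain amine in place of the benzoyl amide.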